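The source may hold more compounds than are shown below. What is called first, only, known or untested is meant among the compounds shown, and "the series" means these compounds.

Three compounds have been measured in an assay on isolated protein for binding affinity to Equilibrative nucleoside transporter 1 (Homo sapiens); on this read-out higher numbers stand for weaker inhibition and lower numbers for stronger inhibition:
Compound 1 `OC[C@H]1O[C@@H](n2cnc3c(CSc4ccc(Cl)c(Cl)c4)ncnc32)[C@H](O)[C@@H]1O` gives 224 nM in this assay.
Compound 2 `OC[C@H]1O[C@@H](n2cnc3c(CSc4ccc(Br)cc4)ncnc32)[C@H](O)[C@@H]1O` gives 178 nM in this assay.
Compound 3 `N#Cc1ccc(SCc2ncnc3c2ncn3[C@@H]2O[C@H](CO)[C@@H](O)[C@H]2O)cc1` gives 81.3 nM in this assay.

Compound 3 stands lowest of the three: a 2.8-fold lower number from compound 1 to compound 3 (0.44 log units; beyond the scatter) and a 2.2-fold lower number from compound 2 to compound 3 (0.34 log units; beyond the scatter), both beyond the scatter, while a 1.3-fold lower number from compound 1 to compound 2 (0.10 log units; within the scatter) lies within it. Compound 4 `CC(C)(C)c1ccc(SCc2ncnc3c2ncn3[C@@H]2O[C@H](CO)[C@@H](O)[C@H]2O)cc1` differs from compound 3 by tert-butyl in place of cyano on an aromatic carbon. No measured step introduces a tert-butyl, so the only guide is the cyano itself: a 2.2-fold lower number from compound 2 to compound 3 (0.34 log units; beyond the scatter) and a 2.8-fold lower number from compound 1 to compound 3 (0.44 log units; beyond the scatter) show that the cyano gave the lowest number among these three aryl groups, with the bromo and dichloro analogues sitting higher. Removing the cyano in favour of tert-butyl is therefore expected to give back part of that gap, a modest rise in this assay rather than a further fall. Tert-butyl is untested here, and the size of the step is uncertain. Compound 4 is estimated at 180 nM, with a range of 70 nM to 450 nM. That estimate means a 2.2-fold higher number from compound 3 to compound 4 (0.35 log units; beyond the scatter) is expected.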

Compound 4, half-maximal inhibitory concentration: 331000 nM
The estimate for compound 4 lay 1800-fold (3.26 log units) below the measured number; the whole stated range lies below it.
By their numbers in this assay, from the lowest: compound 3; then compounds 2 and 1 (each within the scatter of the next); then compound 4.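

In this assay, for the compounds shown here, the aromatic carbon para to a large group turns out to be far less tolerant than the earlier compounds suggested, since their aryl changes moved the number only modestly or within the scatter. Tert-butyl in this place gives a 4100-fold higher number from compound 3 to compound 4 (3.61 log units; beyond the scatter), and the loss stays large against the other two aryl groups, with a 1900-fold higher number from compound 2 to compound 4 (3.27 log units; beyond the scatter) and a 1500-fold higher number from compound 1 to compound 4 (3.17 log units; beyond the scatter), so it does not depend on cyano as the point of comparison. Nothing available explains why this one change costs so much.

The compounds leave open whether a methyl or an isopropyl at this carbon would stay close to compound 3 or fall towards compound 4. They also leave open how a methoxy, an amine or a carboxylic acid would read there.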